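A chain in place of an aryl on the ring nitrogen

The source may hold more compounds than are shown below. What is called first, only, known or untested is meant among the compounds shown, and "the series" means these compounds.

For the measured compounds named here, in a functional assay on CHO cells with adenosine receptor A1 (Homo sapiens) as the target, read by cAMP accumulation and immunoassay, with a stated time of 6 min, tested at 1 uM (on this read-out lower numbers stand for a stronger effect and higher numbers for a weaker effect at the one concentration tested), compound 3 `Nc1scc(CN2CCN(c3c(F)cccc3F)CC2)c1C(=O)c1ccc(Cl)cc1` gives -65%, the lowest of the three numbers measured so far. Compound 2 `Nc1scc(CN2CCN(c3ccc(OC(F)(F)F)cc3)CC2)c1C(=O)c1ccc(Cl)cc1` gives -51% and compound 1 `Nc1scc(CN2CCN(c3ccccc3C(F)(F)F)CC2)c1C(=O)c1ccc(Cl)cc1` gives -39%. The measured steps were all modest: a number 12 percentage points lower from compound 1 to compound 2 (beyond the scatter), a number 14 percentage points lower from compound 2 to compound 3 (beyond the scatter) and a number 26 percentage points lower from compound 1 to compound 3 (beyond the scatter). Compound 4 `Nc1scc(CN2CCN(CCCc3ccc(Cl)cc3)CC2)c1C(=O)c1ccc(Cl)cc1` differs from compound 3 as follows: 3-(4-chlorophenyl)propyl in place of 2,6-difluorophenyl on an amine nitrogen in a ring. Going by the values given here, each measured step exchanged one aryl group for another on the amine nitrogen in a ring; none exchanged an aryl for a chain, so no step bears directly on this change. Given the modest size of those steps, a modest step toward higher numbers, or none beyond the scatter, is expected, as a number 25 percentage points higher from compound 3 to compound 4 (beyond the scatter). Compound 4 is therefore estimated at -40%, with a range from -75% to 0%.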

Compound 4, a percentage reported as activity, at one concentration (the size of the read-out at that concentration, not a potency): -30%
For compound 4 the middle estimate is 10 percentage points below the measured one, within the range that was stated.
By their numbers in this assay, from the lowest: compound 3; then compound 2; then compounds 1 and 4 (each within the scatter of the next).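

In this assay, the only chain shown on this amine nitrogen, 3-(4-chlorophenyl)propyl, gives a large step away from the 2,6-difluorophenyl compound, a number 35 percentage points higher from compound 3 to compound 4 (beyond the scatter), and a modest one away from the 4-(trifluoromethoxy)phenyl compound, a number 21 percentage points higher from compound 2 to compound 4 (beyond the scatter). Against 2-(trifluoromethyl)phenyl the result is a number 9 percentage points higher from compound 1 to compound 4 (within the scatter), so the chain cannot be told apart from that aryl, and an aryl directly on the nitrogen does not by itself set the number. No measurement shown here accounts for these differences. From the compounds shown here alone, with one chain only, it stays open how the number depends on chain length. A shorter 2-(4-chlorophenyl)ethyl chain, or a propyl chain ending in an unsubstituted phenyl, could separate the contribution of the chain from that of its chlorine.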